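Swapping Benzoyl for a Sulfonyl on a Thiazole Amine

A few compounds are considered here, and "the series" means these few. Any claim that something is new, unique, unknown or untested is made for them only; others in the source may bear on it.

The set is small and speaks mostly through absences. Compound 1 `O=C(Nc1ncc(Cc2ccc(F)cc2)s1)c1ccccc1` was tested in an ADME assay on HepG2 2.2.15 cells (Homo sapiens) for cytotoxicity (a lower number here means that less compound is tolerated, a higher number that more compound is tolerated), and compound 1 came out as "not toxic" (no number reported). Compound 2 `O=C(CCCCC(=O)Nc1ncc(Cc2ccc(F)cc2)s1)Nc1ncc(Cc2ccc(F)cc2)s1`, a dimer built on the same thiazole amine, gave in this assay for compound 2 a limit, > 50000 nM, rather than a number. Compound 3 `O=C(Nc1ncc(C(Oc2ccc3cc(Br)ccc3c2)c2ccc(Cl)cc2)s1)c1ccccc1`, the bulkier ether-bearing analogue, is also recorded in this assay only as "not toxic" (no number reported). So compound 3 stands without a single number: one companion value is a limit of the assay and the other is a verdict without a figure, and the limit of > 50000 nM in this assay, at which 1 of the 3 values shown sits, marks where the only numerical entry sits.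

Compound 4 `O=S(=O)(Nc1ncc(C(Oc2ccc3cc(Br)ccc3c2)c2ccc(Cl)cc2)s1)c1ccc(Cl)nc1` keeps everything in compound 3 except the group on the thiazole nitrogen, where ((6-chloropyridin-3-yl)sulfonyl in place of benzoyl on a nitrogen on an aromatic ring). Among the compounds with values here, no measured pair differs in one place, so no step size is recorded to lean on. With all three values shown sitting at or beyond the ceiling of this assay, no step beyond the scatter is expected in either direction. Compound 4 is estimated to show a half-maximal cytotoxic concentration of about 50000 nM, within 20000 nM to 120000 nM, most probably reported again as a limit.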

Compound 4, half-maximal cytotoxic concentration: "not toxic" (no number reported)
For compound 4 the study gives words and no number; there is nothing to compare the estimate with.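

Compound 3 and compound 4 are both recorded in this assay only in words, without a figure, so no step can be read between them. The compounds shown leave open the concentration at which either compound would harm these cells, and whether the change from benzoyl to (6-chloropyridin-3-yl)sulfonyl shifts that concentration at all.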